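Shifting the Chlorine Atom: From Compound 1 to Compound 4

The compounds below may be only part of what the source reports. "The series", "measured", "known", "first", "only" and "open" are said of these compounds alone.

Measured compounds:
compound 1, `Oc1ccc(-c2cc(-c3cccc(Cl)c3)nc(-c3ccccn3)c2)cc1`, 27900 nM
compound 2, `Oc1cccc(-c2cc(-c3cccc(Cl)c3)nc(-c3ccccn3)c2)c1`, "not determined" (no result reported)
compound 3, `Oc1ccc(-c2cc(-c3ccncc3)nc(-c3cccc(Cl)c3)c2)cc1`, "not determined" (no result reported)

Among the compounds with values here, in a functional assay on T47D cells (Homo sapiens) for cytotoxicity, read by CCK-8 assay and cell counting, with a stated time of 2 days (on this read-out higher numbers stand for weaker inhibition and lower numbers for stronger inhibition), compound 1 gives 27900 nM and is the only compound of the set with a number. Within the data shown here, compound 2 and compound 3 were tested without a reported result, so no step between measured compounds can be drawn. Compound 4, `Oc1ccc(-c2cc(-c3ccc(Cl)cc3)nc(-c3ccccn3)c2)cc1`, has not been measured. It differs from compound 1 in one place: 4-chlorophenyl in place of 3-chlorophenyl on an aromatic carbon. The expectation rests on compound 1 alone, whose 27900 nM sets the anchor. A shift beyond the usual scatter in either direction is not expected, so the implied step is estimated as a 1.1-fold lower number from compound 1 to compound 4 (0.05 log units; within the scatter). Compound 4 is therefore expected to give 25000 nM in this assay, within a range from 8000 nM to 80000 nM.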

Compound 4, half-maximal inhibitory concentration: 25900 nM
The estimate for compound 4 lay 1.0-fold (0.02 log units) below the measured number, within the range that was stated.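

In this assay, within the data shown here, the swap of 3-chlorophenyl for 4-chlorophenyl gives a 1.1-fold lower number from compound 1 to compound 4 (0.03 log units; within the scatter) and is the first step in the set that can be read. At this place on the shared core, the two chlorine positions therefore cannot be told apart by this read-out. Nothing available explains this result.

The compounds shown leave open whether an amine or a carboxylic acid in place of the chlorine would change the number. They also leave open whether a chlorophenyl group is needed at this place at all.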